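Chloro for hydrogen on a second core: an expected step

The source may report more compounds than this note shows. Statements on the series, on what has been measured and on what is new or still open speak of the compounds shown alone.

Compound 1, with the structure `COC(=O)C1=C(N)Oc2ccc(Br)cc2C1CC(=O)c1ccccc1`, is the reference point of this small series. In a functional assay on MCF7 cells (Homo sapiens) for antiproliferative activity, read by sulforhodamine B assay, with a stated time of 72 h, tested at 10 uM (a lower number here means a stronger effect, a higher number a weaker effect of the compound at the concentration tested), compound 1 gives 107%. Compound 2, with the structure `COC(=O)C1=C(N)Oc2ccc(Br)cc2C1CC(=O)c1ccc(Cl)cc1`, differs from it in one place: chloro in place of hydrogen on an aromatic carbon. In this assay compound 2 gives 67.6%. This single change produced a step of a number 39.4 percentage points lower from compound 1 to compound 2 (beyond the scatter), a considerable shift for the substitution of a single chlorine for a hydrogen.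

Compound 3 carries a different core, with the structure `COc1cc(Br)cc2c1OC(N)=C(C#N)C2CC(=O)c1ccccc1`, and the difference between the two cores is not broken down here. In this assay compound 3 gives 99.1%, close to the value of compound 1 and well apart from the value of compound 2.

Compound 4, with the structure `COc1cc(Br)cc2c1OC(N)=C(C#N)C2CC(=O)c1ccc(Cl)cc1`, has not yet been measured. It relates to compound 3 exactly as compound 2 relates to compound 1: chloro in place of hydrogen on an aromatic carbon. The place of the change reads the same in both pairs, so this is the same change made on a second core.

Among the compounds with values here, it is expected that this change will again lower the number, by a step of about a number 31.1 percentage points lower from compound 3 to compound 4 (beyond the scatter), because the only measured example of it, a number 39.4 percentage points lower from compound 1 to compound 2 (beyond the scatter), was large and beyond the scatter. Since a single precedent on a different core is a thin basis, the range is kept wide. For compound 4 in this assay the estimate is 68%, with a likely range from 45% to 95%.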

Compound 4, a percentage reported as activity, at one concentration (the size of the read-out at that concentration, not a potency): 49.6%
Compound 4: middle estimate off by 18.4 percentage points, on the high side; measured number inside the range.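

Chloro in place of hydrogen gives a number 49.5 percentage points lower from compound 3 to compound 4 (beyond the scatter) in this assay, so the number falls on the second core as it did on the first. Two pairs read at a single concentration do not explain why the change has this effect, do not give a potency for any compound, and cannot speak for a third core. What they do show is that, for these two cores, phenyl to 4-chlorophenyl carries over with no difference in step size that can be told from the scatter: the same change on two cores in this assay, a number 39.4 percentage points lower (beyond the scatter) from compound 1 to compound 2 and a number 49.5 percentage points lower (beyond the scatter) from compound 3 to compound 4, 10.1 percentage points apart, within the scatter of two such steps

Both chlorine-bearing compounds have the chloro at the same place on the aromatic ring, so the compounds shown leave open whether another group there, such as fluoro, methoxy or an amine, would give a step of similar size. They also leave open how the effect of compound 2 and compound 4 changes with concentration, as each compound is shown at only one.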